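Galloyl glycosides: aglycone exchange from compound 2 to compound 4

The source may report more compounds than this note shows. Statements on the series, on what has been measured and on what is new or still open speak of the compounds shown alone.

Measured so far in a functional assay, read by spectrophotometry, with a stated time of 30 min, tested at 2.5 uM; on this read-out lower numbers stand for a weaker effect and higher numbers for a stronger effect at the one concentration tested:
compound 1 `CC1=CC[C@@H](C(C)(C)O[C@@H]2O[C@H](COC(=O)c3cc(O)c(O)c(O)c3)[C@@H](O)[C@H](O)[C@H]2O)CC1` gives 14.8%;
compound 2 `CC1=CC[C@H](C(C)(C)O[C@@H]2O[C@H](COC(=O)c3cc(O)c(O)c(O)c3)[C@@H](O)[C@H](O)[C@H]2O)CC1` gives 12.9%;
compound 3 `C=CCc1cc(OC)c(O)c(O[C@@H]2O[C@H](COC(=O)c3cc(O)c(O)c(O)c3)[C@@H](O)[C@H](O)[C@H]2O)c1` gives 12.2%.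

Compound 2 stands second highest of the three, with compound 3 nearest and compound 1 furthest, both within the scatter. Within the data shown here, the only measured step, a number 1.9 percentage points lower from compound 1 to compound 2 (within the scatter), rests on the fact that compounds 1 and 2 differ only in the configuration as drawn and concerns configuration alone, so it does not bear on an aglycone exchange.

Compound 4 `C=CCc1ccc(O[C@@H]2O[C@H](COC(=O)c3cc(O)c(O)c(O)c3)[C@@H](O)[C@H](O)[C@H]2O)c(OC)c1` differs from compound 2 by 4-allyl-2-methoxyphenyl in place of 1-methyl-1-(4-methylcyclohex-3-en-1-yl)ethyl on an oxygen on a saturated carbon. Compound 3 carries the same entering group in a different arrangement and gives 12.2%, and all three numbers sit within the scatter of one another. Compound 4 is therefore expected at 12.5%, range 5% to 22%. The expected step is a number 0.4 percentage points lower from compound 2 to compound 4 (within the scatter), none beyond the scatter.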

Compound 4, a percentage reported as activity, at one concentration (the size of the read-out at that concentration, not a potency): 15%
Compound 4: the middle estimate sits 2.5 percentage points below what was measured; the measured number falls inside the stated range.
By their numbers in this assay, from the lowest: compounds 3, 2, 1 and 4 (each within the scatter of the next).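

In this assay, the exchange at this oxygen on a saturated carbon reads as a number 2.1 percentage points higher from compound 2 to compound 4 (within the scatter) and as a number 0.2 percentage points higher from compound 1 to compound 4 (within the scatter), so neither configuration of the leaving group separates itself from the aromatic 4-allyl-2-methoxyphenyl. On this read-out, a saturated-ring aglycone and an aromatic one cannot be told apart at this position. Nothing at hand gives a reason for either step.

From the compounds shown here alone, an aglycone carrying an amine, a carboxylic acid or a longer alkyl chain at this oxygen remains open. So does the effect at any other concentration: each number gives only the size of the effect at the one concentration tested.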